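Replacing the benzyl arm of compound 2 with a tert-butyl ester

A few compounds are considered here, and "the series" means these few. Any claim that something is new, unique, unknown or untested is made for them only; others in the source may bear on it.

Among the measured compounds shown here, compound 2 `COc1ccc(CNC(=O)c2[nH]cnc2C(=O)Nc2ccc(Cl)c(Cl)c2)cc1` holds the highest of the two numbers so far in a functional assay on HL-60 cells (Homo sapiens), with a stated time of 4 days; on this read-out lower numbers stand for stronger inhibition and higher numbers for weaker inhibition: compound 2 gives 18300 nM, whereas compound 1 `O=C(Nc1ccc(Cl)c(Cl)c1)c1nc[nH]c1C(=O)NCc1ccc(Cl)cc1` gives 8800 nM. For the measured compounds named here, the only measured step, a 2.1-fold higher number from compound 1 to compound 2 (0.32 log units; beyond the scatter), concerns a substituent on the aromatic ring that is now removed altogether, so it bears on the present change only loosely. Compound 3 `CC(C)(C)OC(=O)CNC(=O)c1[nH]cnc1C(=O)Nc1ccc(Cl)c(Cl)c1` differs from compound 2 by tert-butoxycarbonyl in place of 4-methoxyphenyl on a saturated chain carbon bound to an amide-type nitrogen. Going by the values given here, no measured step covers removal of this aromatic ring. A modest weakening, a 1.6-fold higher number from compound 2 to compound 3 (0.21 log units; within the scatter), is therefore expected, with a wide range. Compound 3 is estimated at 30000 nM, between 8000 nM and 100000 nM.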

Compound 3, half-maximal inhibitory concentration: 25400 nM
Compound 3: the middle estimate sits 1.2-fold (0.07 log units) above what was measured; the range from low to high includes it.
By their numbers in this assay, from the lowest: compound 1; then compounds 2 and 3 (each within the scatter of the next).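

In this assay, this saturated chain carbon bound to an amide-type nitrogen accepts a ring-free arm: tert-butoxycarbonyl in place of 4-methoxyphenyl leaves a 1.4-fold higher number from compound 2 to compound 3 (0.14 log units; within the scatter) and so no reading of a change. Set against the 4-chlorophenyl arm, the same ester gives a 2.9-fold higher number from compound 1 to compound 3 (0.46 log units; beyond the scatter) as the largest step in the series so far. No evidence on the cause accompanies these steps. Still open, as far as these compounds go, is whether a carboxylic acid in place of the tert-butyl ester, or an amine on a longer chain, stays at this level.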